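Amide to Urea Exchange on a Pyrazole Scaffold

The source may hold more compounds than are shown below. What is called first, only, known or untested is meant among the compounds shown, and "the series" means these compounds.

Compound 1 `O=C(Nc1cccc(-n2cc(-c3ccncc3)c(-c3ccc(Cl)c(O)c3)n2)c1)Nc1ccc(Cl)c(Cl)c1`: 1100 nM
Compound 2 `COc1cc(-c2nn(-c3cccc(NC(=O)c4ccc(Cl)c(C(F)(F)F)c4)c3)cc2-c2ccncc2)ccc1Cl`: 660 nM

In a functional assay on MDA-MB-435 cells (Homo sapiens) for inhibition, read by sulforhodamine B assay, with a stated time of 48 h (on this read-out lower numbers stand for stronger inhibition and higher numbers for weaker inhibition), compound 1 gives 1100 nM, and compound 2 gives 660 nM. Compound 2 thus holds the lower of the two numbers, though the gap to compound 1 lies within the usual scatter, so no order between them can be claimed.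

Compound 3 `COc1cc(-c2nn(-c3cccc(NC(=O)Nc4cccc(C(F)(F)F)c4)c3)cc2-c2ccncc2)ccc1Cl` differs from compound 2 in one place: (3-(trifluoromethyl)phenyl)amino in place of 4-chloro-3-(trifluoromethyl)phenyl on a carbonyl carbon. Among the measured compounds shown here, no measured pair shows this change. Since both measured compounds sit close together, the step is expected to be small, with no direction beyond the scatter, giving a 1.2-fold higher number from compound 2 to compound 3 (0.08 log units; within the scatter). Compound 3 is therefore estimated at 800 nM, within 300 nM to 2500 nM.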

Compound 3, half-maximal inhibitory concentration: 870 nM
The estimate for compound 3 lay 1.1-fold (0.04 log units) below the measured number, within the range that was stated.
By their numbers in this assay, from the lowest: compounds 2, 3 and 1 (each within the scatter of the next).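

On a carbonyl carbon whose other neighbours are an amide-type nitrogen, placing (3-(trifluoromethyl)phenyl)amino where 4-chloro-3-(trifluoromethyl)phenyl stood gives a 1.3-fold higher number from compound 2 to compound 3 (0.12 log units; within the scatter) in this assay and stays within the scatter. This position therefore tolerates a change that adds one hydrogen-bond donor and loses the chlorine, with no readable shift in the number. Nothing given here accounts for this result.

The step alters the nitrogen and the chlorine together, and the two cannot be separated. Going by these compounds, whether (4-chloro-3-(trifluoromethyl)phenyl)amino or a morpholine at this carbonyl carbon would give a similar number remains open.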